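Swapping Methoxy for Cyano: Compound 3 to Compound 4

The source may hold more compounds than are shown below. What is called first, only, known or untested is meant among the compounds shown, and "the series" means these compounds.

Measured compounds and their values:
compound 1 `CC1CCN(C(=S)SCc2ccc(C(=O)Nc3ccccc3N)cc2)CC1` gives 81.9%
compound 2 `Nc1ccccc1NC(=O)c1ccc(CSC(=S)N2CCCc3ccccc32)cc1` gives 87.5%
compound 3 `COc1ccc(N2CCN(C(=S)SCc3ccc(C(=O)Nc4ccccc4N)cc3)CC2)cc1` gives 22.9%

All three were tested in a functional assay on MGC-803 cells (Homo sapiens) for antiproliferative activity, read by CCK-8 assay, with a stated time of 72 h, tested at 8 uM; a higher number here means a stronger effect of the compound at the concentration tested, a lower number a weaker effect. Among the measured compounds shown here, compound 1 and compound 2 sit close together: the one measured step between them, a number 5.6 percentage points higher from compound 1 to compound 2 (within the scatter), changes the group on the thiocarbonyl carbon and lies within the scatter. Compound 3 stands lowest of the three numbers, well beyond the scatter below both compound 1 and compound 2, so the phenylpiperazine group in compound 3 goes with a far weaker effect than the smaller rings of the other two.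

Compound 4 `N#Cc1ccc(N2CCN(C(=S)SCc3ccc(C(=O)Nc4ccccc4N)cc3)CC2)cc1` keeps the structure of compound 3 and differs in one place: cyano in place of methoxy on an aromatic carbon. For the measured compounds named here, no measured step touches this phenyl ring; the only measured step, from compound 1 to compound 2, changes a different part of the molecule and was within the scatter, so it gives no guidance on direction here. Without a comparable step, the expectation rests on compound 3 alone. Compound 4 is therefore estimated to give about 32%, with a range from 10% to 65%. That estimate means an expected step of a number 9.1 percentage points higher from compound 3 to compound 4 (within the scatter), not expected to reach beyond the scatter in either direction.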

Compound 4, a percentage reported as inhibition, at one concentration (the size of the read-out at that concentration, not a potency): 37.6%
Compound 4: the middle estimate sits 5.6 percentage points below what was measured, within the range that was stated.
By their numbers in this assay, from the lowest: compound 3; then compound 4; then compounds 1 and 2 (each within the scatter of the next).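

In this assay the change from 4-methoxyphenyl to 4-cyanophenyl gives a number 14.7 percentage points higher from compound 3 to compound 4 (beyond the scatter), so this aromatic carbon is a place where a small swap can shift the read-out by a modest amount, even though both groups have 2 heavy atoms and 1 hydrogen-bond acceptor. Among the compounds shown here, the earlier compounds could not show this: their single one-place step changed the group on the thiocarbonyl carbon and stayed within the scatter, while this step touches the phenyl ring and goes beyond it. Nothing measured here bears on why the swap moves the number.

The compounds shown leave open whether this carbon responds to other groups, such as a fluorine atom, an amine or a carboxylic acid, or to a plain hydrogen, and so whether the read-out follows any trend across substituents or the cyano result stands alone. They also leave open whether the same swap would matter in a different compound, and whether it would hold at other concentrations, since this read-out comes from one concentration and is not a potency.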